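Working notes: amine substituents on the saturated ring carbon

The source may hold more compounds than are shown below. What is called first, only, known or untested is meant among the compounds shown, and "the series" means these compounds.

The three measured compounds share one core and differ only in the amino group on a saturated ring carbon. Compound 1 `OCCC(NC1CCN(CCCc2c[nH]c3ccc(-n4cnnc4)cc23)CC1)c1ccccc1` gives 5.1 nM in an assay on CHO cells for agonist activity at 5-hydroxytryptamine receptor 1D (Homo sapiens), read by GTPgammaS binding; a higher number here means that more compound is needed for the effect, a lower number that less compound is needed. Compound 2 `CC(C)=CCN(C)C1CCN(CCCc2c[nH]c3ccc(-n4cnnc4)cc23)CC1` gives 1.8 nM. Compound 3 `CN(Cc1cccs1)C1CCN(CCCc2c[nH]c3ccc(-n4cnnc4)cc23)CC1` gives 3.5 nM; its number is the second highest of the three, within the scatter of both neighbours, with a 1.5-fold lower number from compound 1 to compound 3 (0.16 log units; within the scatter) on one side and a 1.9-fold higher number from compound 2 to compound 3 (0.29 log units; within the scatter) on the other. Among the compounds with values here, the only step beyond the scatter is a 2.8-fold lower number from compound 1 to compound 2 (0.45 log units; beyond the scatter).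

Compound 4 `CC(CO)(NC1CCN(CCCc2c[nH]c3ccc(-n4cnnc4)cc23)CC1)c1ccccc1` is not yet measured. Against compound 3 the change is (1-(hydroxymethyl)-1-phenylethyl)amino in place of methyl((thiophen-2-yl)methyl)amino on a saturated ring carbon. The entering group returns to the pattern of compound 1, a secondary amine carrying a phenyl and a hydroxyl, so the step that bears most is a 1.5-fold lower number from compound 1 to compound 3 (0.16 log units; within the scatter), which was small. No larger shift is therefore expected; compound 4 is estimated at 5 nM (range 2 nM to 14 nM), a step of a 1.4-fold higher number from compound 3 to compound 4 (0.15 log units; within the scatter) that is expected to stay within the scatter.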

Compound 4, half-maximal effective concentration: 3.4 nM
For compound 4 the middle estimate is 1.5-fold (0.17 log units) above the measured one; the measured number falls inside the stated range.
By their numbers in this assay, from the lowest: compounds 2, 4, 3 and 1 (each within the scatter of the next, the first and the last beyond it).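

In this assay, a 1.0-fold lower number from compound 3 to compound 4 (0.01 log units; within the scatter) shows that a secondary amine bearing 1-(hydroxymethyl)-1-phenylethyl and a tertiary amine bearing a thiophen-2-ylmethyl group can be exchanged on this saturated ring carbon with no readable shift. Rearranging the hydroxyl and phenyl chain on the amine nitrogen also leaves the number unresolved, with a 1.5-fold lower number from compound 1 to compound 4 (0.18 log units; within the scatter). The step from the methyl(3-methylbut-2-en-1-yl)amino group, a 1.9-fold higher number from compound 2 to compound 4 (0.28 log units; within the scatter), places all three substituent changes involving compound 4 inside the scatter, although compounds 1 and 2 remain apart. No supporting evidence is available to explain these results.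

Still open, on these data alone, is whether the hydroxyl matters, which a 1-methyl-1-phenylethyl group on the amine nitrogen would test. A primary amine or a carboxylic acid at the same ring carbon also remains uncharted.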